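The source may report more compounds than this note shows. Statements on the series, on what has been measured and on what is new or still open speak of the compounds shown alone.

Working notes on the series. All compounds share one core. Compound 1 `Cc1cccc(S(=O)(=O)NCc2ccc(CNC(=O)c3cccnc3)cc2)c1` gives 10 nM in an assay on MDA-MB-231 cells for displacement of a labelled ligand from C-X-C chemokine receptor type 4 (Homo sapiens), read by fluorescence and microscopy, with stated times of 10 min and 30 min; on this read-out higher numbers stand for an effect only at larger amounts of compound and lower numbers for an effect already at smaller amounts. Compound 3 `O=C(NCc1ccc(CNS(=O)(=O)c2ccc(Cl)cc2)cc1)c1cccnc1` gives 1000 nM in this assay, a step of a 100-fold higher number from compound 1 to compound 3 (2.00 log units; beyond the scatter). Compound 2 `COc1ccccc1C(=O)NCc1ccc(CNS(=O)(=O)c2cccc3ccccc23)cc1` reads > 1000 nM in this assay, which is a limit rather than a number. It stands at the limit of > 1000 nM in this assay, at which 1 of the 3 values shown sits. The move to compound 4 `COc1ccccc1C(=O)NCc1ccc(CNS(=O)(=O)c2ccc([N+](=O)[O-])cc2)cc1` is 4-nitrophenyl in place of naphthalen-1-yl on a sulfonyl sulfur. Within the data shown here, no measured pair matches this change; the only step on the sulfonyl aryl, a 100-fold higher number from compound 1 to compound 3 (2.00 log units; beyond the scatter), ran toward weaker binding, and compound 2 already sits at the limit, so no gain beyond the scatter is expected. Compound 4 is expected near 1500 nM, within 400 nM to 6000 nM. The implied step that the limit leaves unreadable from compound 2 to compound 4 is an estimate only.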

Compound 4, effective concentration (reported as EC, without a stated level of effect): 100 nM
Compound 4: the middle estimate sits 15-fold (1.18 log units) above what was measured, outside the stated range (below it).
By their numbers in this assay, from the lowest: compound 1; then compound 4; then compound 3.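

With the rest of compound 2 unchanged, 4-nitrophenyl in place of naphthalen-1-yl on a sulfonyl sulfur gives an at least 10-fold lower number from compound 2 to compound 4 (1.00 log units; beyond the scatter) in this assay. The group at this position can therefore lower the number as well as raise it, the opposite direction to a 100-fold higher number from compound 1 to compound 3 (2.00 log units; beyond the scatter), though that step sits on a different amide side. The full size of the new step stays unread: the limit of > 1000 nM in this assay, at which 1 of the 4 values shown sits.

On these data alone, whether 4-nitrophenyl and 4-chlorophenyl would differ on one shared core remains open. Also open, as far as these compounds go, is how an amine or a carboxylic acid on the aryl group at this position would read.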